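Trimethoxyphenyl Isomer Swap on a Semicarbazone Series

The source may report more compounds than this note shows. Statements on the series, on what has been measured and on what is new or still open speak of the compounds shown alone.

Compound 1 `CN(C)CCn1cnnc1-c1cc(Oc2ccc(NC(=O)N/N=C/c3c[nH]c4ccccc34)cc2F)ccn1`: 820 nM
Compound 2 `COc1ccc(/C=N/NC(=O)Nc2ccc(Oc3ccnc(-c4nncn4CCN(C)C)c3)c(F)c2)c(OC)c1OC`: 6680 nM
Compound 3 `CN(C)CCn1cnnc1-c1cc(Oc2ccc(NC(=O)N/N=C/c3ccc(F)cc3)cc2F)ccn1`: 1790 nM

Three compounds sharing one core were tested in a functional assay on A549 cells (Homo sapiens) for cytotoxicity, read by MTT assay, with a stated time of 72 h; a higher number here means a weaker inhibitor, a lower number a stronger inhibitor. Compound 3 `CN(C)CCn1cnnc1-c1cc(Oc2ccc(NC(=O)N/N=C/c3ccc(F)cc3)cc2F)ccn1` sits second highest of the three numbers: compound 1 is nearest, with a 2.2-fold higher number from compound 1 to compound 3 (0.34 log units; beyond the scatter), and compound 2 is furthest, with a 3.7-fold lower number from compound 2 to compound 3 (0.57 log units; beyond the scatter).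

Compound 4 `COc1cc(/C=N/NC(=O)Nc2ccc(Oc3ccnc(-c4nncn4CCN(C)C)c3)c(F)c2)cc(OC)c1OC` is not yet measured. It differs from compound 3 in one place: 3,4,5-trimethoxyphenyl in place of 4-fluorophenyl on a carbon with a double bond to nitrogen.

Among the measured compounds shown here, only one measured step bears directly on this change, since it also trades the 4-fluorophenyl for a trimethoxyphenyl, though a differently substituted one: a 3.7-fold lower number from compound 2 to compound 3 (0.57 log units; beyond the scatter), a modest step. Reversing that direction suggests the new substituent will weaken inhibition by a modest amount; the isomer differs, so the size is uncertain.

Compound 4 is therefore expected to give about 4500 nM in this assay, within a range of 1500 nM to 14000 nM, an estimated step of a 2.5-fold higher number from compound 3 to compound 4 (0.40 log units; beyond the scatter).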

Compound 4, half-maximal inhibitory concentration: > 100000 nM
Compound 4 was reported as a limit (the forecaster's own chance of this, stated with the estimate: 5%); at least 22-fold (1.34 log units) between middle value and limit.
By their numbers in this assay, from the lowest: compound 1; then compound 3; then compound 2. At a limit, above all of these: compound 4.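

In this assay the result for compound 4 is a limit, not a number: the limit of > 100000 nM in this assay, at which 1 of the 4 values shown sits.

Until now, changes on the carbon with a double bond to nitrogen gave only modest steps, but the 3,4,5-trimethoxyphenyl group gives large ones, both against 4-fluorophenyl (an at least 55-fold higher number from compound 3 to compound 4 (1.74 log units; beyond the scatter)) and against 1H-indol-3-yl (an at least 120-fold higher number from compound 1 to compound 4 (2.08 log units; beyond the scatter)). Three methoxy groups alone do not account for this, since compounds 2 and 4 differ only in their arrangement, as 2,3,4-trimethoxyphenyl and 3,4,5-trimethoxyphenyl (an at least 14-fold higher number from compound 2 to compound 4 (1.17 log units; beyond the scatter)).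

The compounds shown include no 3,5-dimethoxyphenyl or 4-methoxyphenyl group at this place, so which methoxy groups go with the large step stays open. Why this arrangement behaves so differently also stays open.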